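The source may hold more compounds than are shown below. What is called first, only, known or untested is meant among the compounds shown, and "the series" means these compounds.

Measured in a functional assay on PC-3 cells (Homo sapiens) for cytotoxicity, read by sulforhodamine B assay, with a stated time of 48 h; on this read-out lower numbers stand for stronger inhibition and higher numbers for weaker inhibition:
- Compound 1 `CC1(C)CNC(=O)c2cc(-c3ccc([N+](=O)[O-])cc3)n(-c3ccc(Cl)cc3)c2C1`: 17400 nM
- Compound 2 `CC1(C)CNC(=O)c2cc(-c3ccc([N+](=O)[O-])cc3)n(-c3ccc(Br)cc3)c2C1`: 21100 nM
- Compound 3 `CC1(C)CNC(=O)c2cc3n(c2C1)CCc1cc(Cl)ccc1-3`: > 100000 nM

Compound 3 has no exact number, only a limit: it sits at the limit of > 100000 nM in this assay, at which 1 of the 3 values shown sits.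

Compound 4 `COc1ccc2c(c1)CCn1c-2cc2c1CC(C)(C)CNC2=O` differs from compound 3 by a single change, (methoxy in place of chloro on an aromatic carbon). In words, this is methoxy in place of chloro on an aromatic carbon, part of a fused or bridged system of four rings.

Among the measured compounds shown here, only one measured step offers any guidance, a 1.2-fold higher number from compound 1 to compound 2 (0.08 log units; within the scatter). That step puts bromo in place of chloro on an aromatic carbon, and its size lies within the scatter. For the measured compounds named here, it sits on a different core, and no measured step brings in a methoxy, so it is only a loose guide.

Starting from compound 3, whose value of > 100000 nM is a limit, no step beyond the scatter is expected in this assay. The expected change is a number no higher from compound 3 to compound 4 (the limit leaves the size open). The estimated value for compound 4 is 100000 nM. The expected range for compound 4 runs from 35000 nM to 250000 nM.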

Compound 4, half-maximal inhibitory concentration: > 100000 nM
Compound 4: a limit, no number; the forecaster's own chance of this, stated with the estimate: 65%; the middle value lies on the limit itself.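

In this assay, compound 3 and compound 4 each give only a limit and not a number, so methoxy in place of chloro cannot be read as a step: the limit of > 100000 nM in this assay, at which 2 of the 4 values shown sit. Left open is whether these two compounds differ at all, and by how much.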